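Isopropyl to 1-methylcyclopropyl on two azole ureas

The source may hold more compounds than are shown below. What is called first, only, known or untested is meant among the compounds shown, and "the series" means these compounds.

Compound 1 `CC(C)c1cc(NC(=O)n2ccc3cc(Oc4ncnc5c4CCNC5)ccc32)n[nH]1` and compound 2 `CC1(c2cc(NC(=O)n3ccc4cc(Oc5ncnc6c5CCNC6)ccc43)n[nH]2)CC1` share one core; compound 3 `CC(C)c1cc(NC(=O)n2ccc3cc(Oc4ncnc5c4CNC5)ccc32)no1` sits on a second core, and the difference between the two cores is not broken down here. In a functional assay on the whole organism (strain C57BL/6) for inhibition, with Mus musculus as the target, read by microscopy, with a stated time of 6 days, at a dose of 10 mg/kg by the oral route (a lower number here means less inhibition, a higher number more inhibition at the dose given (going by the name of the read-out)), compound 1 gives 0%, compound 2 gives 64% and compound 3 gives 96%, the highest of the three, its steps to compound 2 and to compound 1 both beyond the scatter.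

Going by the values given here, the one counted change within the first core is 1-methylcyclopropyl in place of isopropyl on an aromatic carbon and it produces a number 64 percentage points higher from compound 1 to compound 2 (beyond the scatter).

Compound 4 `CC1(c2cc(NC(=O)n3ccc4cc(Oc5ncnc6c5CNC6)ccc43)no2)CC1` carries the same kind of change on the core of compound 3: 1-methylcyclopropyl in place of isopropyl on an aromatic carbon. The surroundings differ: in compound 1 the group sits on a five-membered aromatic ring with 2 nitrogen, next to the ring nitrogen, while in compound 3 it sits on a five-membered aromatic ring with 1 nitrogen and 1 oxygen, next to the ring oxygen. Whether the change acts alike on both rings is known from one pair only.

For compound 4 the step is expected to be a number 1 percentage points higher from compound 3 to compound 4 (within the scatter), far smaller than the step within the first core, because compound 3 already gives 96% and inhibition cannot rise much further. Compound 4 is therefore estimated at 97%, with a range from 85% to 100%.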

Compound 4, a percentage reported as inhibition, in the whole organism at one dose (the size of the read-out at that dose, not a potency): 90%
Compound 4: the middle estimate sits 7 percentage points above what was measured; the range from low to high includes it.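

In this assay, 1-methylcyclopropyl in place of isopropyl on the core of compound 3 gives a number 6 percentage points lower from compound 3 to compound 4 (within the scatter), so this pair shows no readable step, and the large gain seen on the first core did not carry over. The size of the step therefore depends on the setting in which the change is made, at least across these two pairs: the same change on two cores in this assay, a number 64 percentage points higher (beyond the scatter) from compound 1 to compound 2 and a number 6 percentage points lower (within the scatter) from compound 3 to compound 4, 70 percentage points apart, beyond the scatter of two such steps

This does not show which part of the setting matters, since the two pairs differ both in the five-membered aromatic ring that carries the group and in the rest of the core, and two pairs give no rule for a further core.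

The compounds shown leave open what the same change does when only one of those differences is present, as it would be with the ring with 1 nitrogen and 1 oxygen on the first core, or the ring with 2 nitrogen on the core of compound 3. Also open, as far as these compounds go, is how other groups on that aromatic carbon, such as tert-butyl or trifluoromethyl, would read in this assay, and how compound 3 and compound 4 would compare at a lower dose.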